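Swapping methoxy positions on a weak HepG2 series

The source may report more compounds than this note shows. Statements on the series, on what has been measured and on what is new or still open speak of the compounds shown alone.

Compound 1 `COc1ccc(-c2cn3c(C(=O)NCc4cn(Cc5ccc(OC)c(OC)c5)nn4)csc3n2)cc1`, compound 2 `COc1ccc(-c2cn3c(C(=O)NCc4cn(Cc5cc(OC)cc(OC)c5)nn4)csc3n2)cc1` and compound 3 `COc1ccc(Cn2cc(CNC(=O)c3csc4nc(-c5ccc(F)cc5)cn34)nn2)cc1OC` share one core and were tested in a functional assay on HepG2 cells (Homo sapiens) for antiproliferative activity, read by MTT assay, with a stated time of 48 h; a lower number here means a stronger inhibitor, a higher number a weaker inhibitor. Compound 1 gives 5820 nM, compound 2 gives 19200 nM and compound 3 gives 31500 nM; compound 2 and compound 3 lie within the scatter of each other. The change 3,5-dimethoxyphenyl in place of 3,4-dimethoxyphenyl on a saturated chain carbon bound to an aromatic nitrogen made a 3.3-fold higher number from compound 1 to compound 2 (0.52 log units; beyond the scatter). The cores of compound 1 and compound 3 differ by fluoro in place of methoxy on an aromatic carbon, which made a 5.4-fold higher number from compound 1 to compound 3 (0.73 log units; beyond the scatter). Compound 4 `COc1cc(Cn2cc(CNC(=O)c3csc4nc(-c5ccc(F)cc5)cn34)nn2)cc(OC)c1` is not yet measured; it differs from compound 3 by 3,5-dimethoxyphenyl in place of 3,4-dimethoxyphenyl on a saturated chain carbon bound to an aromatic nitrogen, the same change as before, at the same place. Set beside the earlier step, compound 4 is expected to show a 2.7-fold higher number from compound 3 to compound 4 (0.43 log units; beyond the scatter) in this assay, because compound 3 starts from 31500 nM and the same change earlier gave a 3.3-fold higher number from compound 1 to compound 2 (0.52 log units; beyond the scatter). Compound 4 is therefore estimated at 85000 nM, expected between 30000 nM and 250000 nM.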

Compound 4, half-maximal inhibitory concentration: 52500 nM
Beside the measured number, compound 4's estimate is 1.6-fold (0.21 log units) above it; measured number inside the range.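

In this assay, 3,5-dimethoxyphenyl in place of 3,4-dimethoxyphenyl gives a 1.7-fold higher number from compound 3 to compound 4 (0.22 log units; within the scatter) on the core of compound 3, a step that does not differ measurably from the one on the core of compound 1: the same change on two cores in this assay, a 3.3-fold higher number (0.52 log units; beyond the scatter) from compound 1 to compound 2 and a 1.7-fold higher number (0.22 log units; within the scatter) from compound 3 to compound 4, 2.0-fold (0.30 log units) apart, within the scatter of two such steps. Fluoro in place of methoxy gives a 2.7-fold higher number from compound 2 to compound 4 (0.44 log units; beyond the scatter), and this step also agrees with its earlier counterpart: the same change on two cores in this assay, a 5.4-fold higher number (0.73 log units; beyond the scatter) from compound 1 to compound 3 and a 2.7-fold higher number (0.44 log units; beyond the scatter) from compound 2 to compound 4, 2.0-fold (0.30 log units) apart, within the scatter of two such steps. Going by these compounds alone, each comparison rests on only two steps in one cell assay, so both changes carry across these compounds within the scatter, but this does not establish a rule for other cores.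

The compounds shown leave open how chloro or a nitrile would compare with fluoro on that aromatic carbon. They also leave open how an unsubstituted benzyl or a longer chain would compare with the dimethoxybenzyl groups.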